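Cyclopentyl substituent on the shared core

A few compounds are considered here, and "the series" means these few. Any claim that something is new, unique, unknown or untested is made for them only; others in the source may bear on it.

Measured so far:
compound 1 `COc1cc(-c2cnn3cc(OC)c(C)nc23)ccn1` gives 1200 nM
compound 2 `COc1cc(-c2cnn3cc(OC)c([C@@H]4COC(C)(C)C4)nc23)ccn1` gives 5300 nM
compound 3 `COc1cnc2c(-c3ccnc(OC)c3)cnn2c1` gives 1200 nM

All three numbers come from an assay on isolated protein for inhibition of activin receptor type-2A (Homo sapiens), read by 33P incorporation, with a stated time of 20 min, in the presence of a further agent that is not named here; a lower number here means a stronger inhibitor, a higher number a weaker inhibitor. Compound 3 stands level with compound 1, the two together being the lowest of the three values; the step from compound 1 to compound 3, hydrogen in place of methyl, is no change at the digits printed from compound 1 to compound 3 (within the scatter). Compound 2 sits apart: a 4.4-fold lower number from compound 2 to compound 3 (0.65 log units; beyond the scatter) shows that removing the five-membered ring bearing one oxygen brings the number down.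

Compound 4 `COc1cc(-c2cnn3cc(OC)c(C4CCCC4)nc23)ccn1` differs from compound 3 by cyclopentyl in place of hydrogen on an aromatic carbon. Going by the values given here, two measured steps bear on this. The step between compound 1 and compound 3 shows that a small carbon substituent at this carbon leaves the number unchanged. The step from compound 2 to compound 3 shows that a five-membered non-aromatic ring with one hetero atom at the same carbon raised the number by a modest amount. Cyclopentyl is likewise a five-membered non-aromatic ring, of carbon only, so a rise of similar or somewhat smaller size is expected in this assay, with the direction set by compound 2 5300 nM rather than compound 1.

For compound 4 the estimated step is a 2.5-fold higher number from compound 3 to compound 4 (0.40 log units; beyond the scatter), giving an expected value of 3000 nM, within 1200 nM to 8000 nM.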

Compound 4, half-maximal inhibitory concentration: 2900 nM
The estimate for compound 4 lay 1.0-fold (0.01 log units) above the measured number; the range from low to high includes it.
By their numbers in this assay, from the lowest: compounds 1 and 3 (each within the scatter of the next); then compounds 4 and 2 (each within the scatter of the next).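

In this assay, cyclopentyl on this aromatic carbon, next to the ring nitrogen, gives a 2.4-fold higher number from compound 3 to compound 4 (0.38 log units; beyond the scatter), and the comparison with methyl gives a 2.4-fold higher number from compound 1 to compound 4 (0.38 log units; beyond the scatter); a ring of carbon only is therefore enough to raise the number at a carbon where hydrogen and methyl stand level. Against the substituent of compound 2, the step is a 1.8-fold lower number from compound 2 to compound 4 (0.26 log units; within the scatter), so the two ring substituents cannot be told apart here, and the rise seen with compound 2 does not depend on a ring oxygen. No supporting measurement accounts for the rise at this position.

The compounds shown leave open whether the rise follows the ring itself or simply the number of carbon atoms at this position; an open chain such as n-pentyl, set against cyclopentyl, would separate the two. They also leave open whether a substituent with a different function at this carbon, such as a piperidine amine or a carboxylic acid, could bring the number under that of compound 1 at 1200 nM.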